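The source may report more compounds than this note shows. Statements on the series, on what has been measured and on what is new or still open speak of the compounds shown alone.

Measured in a functional assay on MDA-MB-435 cells (Homo sapiens) for antiproliferative activity, read by sulforhodamine B assay; on this read-out higher numbers stand for weaker inhibition and lower numbers for stronger inhibition:
- compound 1 `COc1ccc(N(C)c2nc(C)nc3ccccc23)cc1`: 1.7 nM
- compound 2 `CSc1ccc(N(C)c2nc(C)nc3ccccc23)cc1`: 1.2 nM
- compound 3 `COc1ccc2c(c1)CCCN2c1ncnc2ccccc12`: 12.4 nM

Compound 2 stands at the low end of these numbers, level within the scatter with compound 1. Compound 4 `CSc1ccc(N(C)c2ncnc3ccccc23)cc1` is still unmeasured and differs from compound 2 by hydrogen in place of methyl on an aromatic carbon.

Among the compounds with values here, the only measured step, a 1.4-fold lower number from compound 1 to compound 2 (0.15 log units; within the scatter), concerns a different group and says little here. Within the data shown here, no measured step isolates this change. Compound 3 also carries hydrogen on that carbon and gives 12.4 nM, though it differs elsewhere too, so a moderately higher number is expected in this assay.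

The expected change is a 5.0-fold higher number from compound 2 to compound 4 (0.70 log units; beyond the scatter). For compound 4 the estimated value is 6 nM, with an expected range of 1.5 nM to 25 nM.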

Compound 4, half-maximal inhibitory concentration: 7.8 nM
Estimate against measurement, compound 4: 1.3-fold (0.11 log units) below, and the stated range covers the measured number.
By their numbers in this assay, from the lowest: compounds 2 and 1 (each within the scatter of the next); then compounds 4 and 3 (each within the scatter of the next).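

In this assay, within the data shown here, the methyl on the aromatic carbon between two ring nitrogen atoms proves to matter: hydrogen in its place gives a 6.5-fold higher number from compound 2 to compound 4 (0.81 log units; beyond the scatter), the first measured step to isolate this position. With the methylsulfanyl group and the rest of compound 2 unchanged, this change alone moves the number beyond the scatter. The data offer no explanation for the size of this step.

Going by these compounds, whether an ethyl group or an amine on this carbon would retain the low number of compound 2 remains open. So does whether removing the methyl has a similar effect when methoxy replaces methylsulfanyl.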